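A few compounds are considered here, and "the series" means these few. Any claim that something is new, unique, unknown or untested is made for them only; others in the source may bear on it.

Measured compounds:
compound 1 `O=c1c(-c2nn[nH]n2)c[nH]c2ccc(Cl)cc12` — > 10 mg/kg
compound 2 `Cc1ccc2[nH]cc(-c3nn[nH]n3)c(=O)c2c1` — 1.25 mg/kg

Compound 1 `O=c1c(-c2nn[nH]n2)c[nH]c2ccc(Cl)cc12` was examined in a functional assay on the whole organism (strain Sprague-Dawley) for inhibition, with Rattus norvegicus as the target; on this read-out higher numbers stand for an effect only at larger amounts of compound and lower numbers for an effect already at smaller amounts. In this assay compound 1 reaches only a limit of the assay, > 10 mg/kg, and no number. Compound 2 `Cc1ccc2[nH]cc(-c3nn[nH]n3)c(=O)c2c1` differs from compound 1 by methyl in place of chloro on an aromatic carbon, and in this assay compound 2 gives 1.25 mg/kg. This single measured step, an at least 8.0-fold lower number from compound 1 to compound 2 (0.90 log units; beyond the scatter), is the only one available, and it leaves compound 1 standing at the limit (the limit of > 10 mg/kg in this assay, at which 1 of the 2 values shown sits).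

Compound 3 `O=c1c(-c2nn[nH]n2)c[nH]c2c(Cl)cc(Cl)cc12` has not yet been measured. It differs from compound 1 by chloro in place of hydrogen on an aromatic carbon. Among the compounds with values here, no measured step adds a chloro; the one measured step instead exchanges the chloro of compound 1 for methyl and lowers the number. Within the data shown here, the second chloro thus has no direct precedent, and compound 1 itself offers only a limit to start from. The step is estimated as a step that the limit leaves unreadable from compound 1 to compound 3, which amounts to none beyond the scatter. Compound 3 is accordingly expected to give 15 mg/kg, within 5 mg/kg to 45 mg/kg, most likely again only as a limit.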

Compound 3, minimum effective dose: > 0.156 mg/kg
Compound 3: a limit, no number; the forecaster's own chance of this, stated with the estimate: 70%; the middle value lies beyond the limit too.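

Compound 3 gives only a limit in this assay, with no number, and compound 1 does too, so the step between compound 1 and compound 3 cannot be read. The compounds shown leave open whether the added chloro on the aromatic carbon changes the minimum effective dose at all, and in which direction.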